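The source may hold more compounds than are shown below. What is called first, only, known or untested is meant among the compounds shown, and "the series" means these compounds.

Measured compounds:
compound 1, `Cc1cc(Nc2cc(-c3ccccc3)[nH]n2)n2nc(SCc3c(Cl)cccc3Cl)nc2n1`, 3230 nM
compound 2, `Cc1cc(Nc2cc(-c3ccccc3)[nH]n2)n2nc(SCC(=O)c3ccccc3)nc2n1`, 5240 nM
compound 3, `Cc1cc(Nc2cc(-c3ccc(F)cc3)[nH]n2)n2nc(SCc3ccc(Br)cc3)nc2n1`, 4570 nM

In a functional assay on MCF7 cells (Homo sapiens) for inhibition, read by MTT assay, with a stated time of 72 h (a lower number here means a stronger inhibitor, a higher number a weaker inhibitor), compound 1 gives the lowest of the three numbers, but compound 3 and compound 2 both sit within the scatter of it, so no order among them can be claimed.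

Compound 4, `CCCSc1nc2nc(C)cc(Nc3cc(-c4ccccc4)[nH]n3)n2n1`, is not yet measured. It differs from compound 1 as follows: ethyl in place of 2,6-dichlorophenyl on a saturated chain carbon bound to a sulfur

Among the measured compounds shown here, the one measured step at that place is a 1.6-fold higher number from compound 1 to compound 2 (0.21 log units; within the scatter), where a benzoyl group replaced the 2,6-dichlorophenyl and the number barely moved. Here the aromatic ring leaves entirely and only an ethyl enters, a larger change than that step covered, so the evidence is thin. Compound 4 is expected to be a somewhat weaker inhibitor, a 2.0-fold higher number from compound 1 to compound 4 (0.30 log units; within the scatter), though a value within the scatter of compound 1 would not surprise. The estimate for compound 4 is 6500 nM, between 2500 nM and 17000 nM.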

Compound 4, half-maximal inhibitory concentration: > 50000 nM
Compound 4 gave a limit, no number (the forecaster's own chance of this, stated with the estimate: 10%); at least 7.6-fold (0.88 log units) between middle value and limit.
By their numbers in this assay, from the lowest: compounds 1, 3 and 2 (each within the scatter of the next). At a limit, above all of these: compound 4.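

Compound 4 stands at a limit, not a number: the limit of > 50000 nM in this assay, at which 1 of the 4 values shown sits. The earlier step, with benzoyl in place of 2,6-dichlorophenyl, stayed within the scatter and suggested that this position accepts change, but the position proves sensitive to what it carries. Ethyl in place of 2,6-dichlorophenyl gives an at least 15-fold higher number from compound 1 to compound 4 (1.18 log units; beyond the scatter), and ethyl in place of benzoyl gives an at least 9.5-fold higher number from compound 2 to compound 4 (0.97 log units; beyond the scatter).

What the compounds shown leave open is whether an aromatic ring on that chain is itself what counts, or only a group larger than ethyl. A cyclohexyl group or a longer chain such as hexyl at this place would separate these two readings.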